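The source may hold more compounds than are shown below. What is called first, only, known or untested is meant among the compounds shown, and "the series" means these compounds.

Compound 1, `CCC1(Cc2ccccc2)OS(=O)(=O)C=C1OC`: in an ADME assay on HEL cells (Homo sapiens) for cytotoxicity, with a stated time of 3 days (on this read-out lower numbers stand for higher toxicity in this test and higher numbers for lower toxicity in this test), compound 1 gives > 400000 nM, which is a limit of the assay.
Compound 2, `CCC1(Cc2ccccc2)OS(=O)(=O)C=C1OCc1ccc(Cl)cc1`: in this assay compound 2 gives >= 50000 nM, again a limit of the assay.
Compound 3, `CCC1(Cc2ccccc2)OS(=O)(=O)C=C1OCc1ccc(Cl)c(Cl)c1`: in this assay compound 3 gives >= 20000 nM, also a limit of the assay.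

Compound 3 therefore stands only at a limit, and so do the two other values shown, so none of the three can be ranked against another. Compound 4, `CCC1(Cc2ccccc2)OS(=O)(=O)C=C1OCCCc1ccccc1`, differs from compound 3 as follows: phenethyl in place of 3,4-dichlorophenyl on a saturated chain carbon bound to an oxygen on an unsaturated carbon. The measured steps at the same place, a step that the two limits leave unreadable from compound 1 to compound 3 and a step that the two limits leave unreadable from compound 2 to compound 3, cannot be sized because of the limit of > 400000 nM in this assay, at which 1 of the 3 values shown sits, the limit of >= 50000 nM in this assay, at which 1 of the 3 values shown sits, and (the limit of >= 20000 nM in this assay, at which 1 of the 3 values shown sits). For compound 4 no change beyond the scatter is expected, a step that the limit leaves unreadable from compound 3 to compound 4. Compound 4 is estimated at 50000 nM, between 15000 nM and 300000 nM, and is expected once more to be reported only as a limit.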

Compound 4, minimum cytotoxic concentration: >= 20000 nM
Compound 4 ended at the assay's limit; the forecaster's own chance of this, stated with the estimate: 80%; the middle value is on the limit's open side.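

Compound 4, like compound 1, compound 2 and compound 3, stands only at a limit in this assay, so no step among these four compounds can be read. The compounds shown leave open how their minimum cytotoxic concentrations rank.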